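This account rests on a few compounds, and the source may have more. Where it says the series, first, only, none or still open, it means among the compounds named here.

Going by the values given here, compound 1 `O=C(O)CCCCCCn1nc(-c2ccccc2)c(-c2ccccc2)c1-c1ccccc1` is the only compound of the pair with a number in a functional assay for inhibition, with Homo sapiens as the target (on this read-out lower numbers stand for stronger inhibition and higher numbers for weaker inhibition), where compound 1 gives 22400 nM. Compound 2 `O=C(O)CCCCCCn1cc(-c2ccccc2)c(-c2ccccc2)n1` reaches only a limit of the assay in this assay, and compound 2 gives > 92000 nM. Among the compounds with values here, the one measured step, an at least 4.1-fold higher number from compound 1 to compound 2 (0.61 log units; beyond the scatter), removes a phenyl and weakens inhibition, as the limit of > 92000 nM in this assay, at which 1 of the 2 values shown sits, shows. Compound 3 `O=C(O)COCCCCCCn1nc(-c2ccccc2)c(-c2ccccc2)c1-c1ccccc1` differs from compound 1 in another way: carboxymethoxy in place of carboxy on a saturated chain carbon, six bonds along the chain from an aromatic nitrogen. Within the data shown here, no measured step touches the carboxy end of the chain, so the step from the phenyl removal gives no direct guide to this change. The chain is lengthened by the carboxymethoxy group while the acid is kept, and compound 3 is therefore expected to show a step of a 1.1-fold higher number from compound 1 to compound 3 (0.05 log units; within the scatter), that is no change beyond the scatter. For compound 3 the estimate in this assay is 25000 nM, with a range from 8000 nM to 80000 nM.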

Compound 3, half-maximal inhibitory concentration: 440 nM
Beside the measured number, compound 3's estimate is 57-fold (1.75 log units) above it; the measured number lies below the stated range.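

In this assay, carboxymethoxy in place of carboxy on a saturated chain carbon, six bonds along the chain from an aromatic nitrogen, gives a 51-fold lower number from compound 1 to compound 3 (1.71 log units; beyond the scatter). Going by these compounds alone, this shows that the carboxy end of the chain, which no earlier step touched, strongly affects inhibition, and that a large gain is possible with an acid kept at this end. Nothing in the evidence shown accounts for this gain.

The compounds shown do not separate the effect of the added oxygen from that of the added length, which a plain carbon chain of matching length or a sulfur atom in place of that oxygen could address. Also open, on these data alone, are whether the gain carries over to the core of compound 2 and whether a tetrazole in place of the carboxylic acid would retain it.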